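Swapping propyl for allyl on an antiviral-type nucleoside analogue

The source may report more compounds than this note shows. Statements on the series, on what has been measured and on what is new or still open speak of the compounds shown alone.

Compound 1 has the structure `CCCOc1nc(N)nc2c1ncn2/C=C1/CC1(CO)CO`. In an ADME assay on Akata cells (Homo sapiens) for cytotoxicity, with a stated time of 7 days (a lower number here means that less compound is tolerated, a higher number that more compound is tolerated), compound 1 gives > 20000 nM, which is a limit of the assay rather than a measured number. A close relative, compound 2 `CCCCCOc1nc(N)nc2c1ncn2/C=C1/CC1(CO)CO`, carries a longer chain on the same oxygen. In this assay compound 2 gives > 20000 nM, again a limit of the assay. Within the data shown here, the one measured step, a step that the two limits leave unreadable from compound 1 to compound 2, therefore cannot be read as a number; both values sit at the same point, as summed up by the limit of > 20000 nM in this assay, at which 2 of the 2 values shown sit.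

The compound not yet measured is compound 3 `C=CCOc1nc(N)nc2c1ncn2/C=C1/CC1(CO)CO`. It differs from compound 1 by vinyl in place of ethyl on a saturated chain carbon bound to an oxygen on an aromatic ring. Among the measured compounds shown here, the only measured step changes the same chain, and it shows no shift that could be read at all, so nothing among the measured values points to a change in either direction. The expectation for compound 3 is therefore that this assay again returns a limit, and the estimated step that the limit leaves unreadable from compound 1 to compound 3 is expected to be nothing beyond the scatter. Compound 3 is accordingly estimated at 40000 nM in this assay, with a range from 15000 nM to 100000 nM.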

Compound 3, half-maximal cytotoxic concentration: > 20000 nM
Compound 3: no number, only a limit; the forecaster's own chance of this, stated with the estimate: 85%; the middle value lies beyond the limit too.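

Compound 3, like compound 1 and compound 2, gives only a limit of the assay in this assay, so no step among these compounds can be read. The compounds shown leave open at what concentration each one harms these cells, and whether swapping propyl for allyl changes that concentration at all: the limit of > 20000 nM in this assay, at which 3 of the 3 values shown sit.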